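A few compounds are considered here, and "the series" means these few. Any claim that something is new, unique, unknown or untested is made for them only; others in the source may bear on it.

Compound 1, `CCn1c(=S)[nH]c2c(cc(-c3ccccc3)n2-c2ccccc2)c1=N`, gives 65% in a functional assay on the whole organism for inhibition, with Rattus norvegicus as the target, read by ELISA, with stated times of 30 min and 6 h, at a dose of 30 mg/kg by the oral route; on this read-out lower numbers stand for less inhibition and higher numbers for more inhibition at the one dose given (going by the name of the read-out).
Compound 2, `CCn1c(=S)[nH]c2c(cc(-c3ccc(Cl)cc3)n2-c2ccccc2)c1=N`, gives 61% in this assay.
Compound 3, `CCn1c(=S)[nH]c2c(cc(-c3ccc(C)cc3)n2-c2ccccc2)c1=N`, gives 60% in this assay.

Among the compounds with values here, compound 1 has the highest number of the measured set, yet its steps to compound 2, a number 4 percentage points lower from compound 1 to compound 2 (within the scatter), and to compound 3, a number 5 percentage points lower from compound 1 to compound 3 (within the scatter), both lie within the scatter, so none of the measured compounds can be called stronger than another. Compound 4, `N=c1c2cc(-c3ccccc3)n(-c3ccccc3)c2[nH]c(=S)n1N`, differs from compound 1 by amino in place of ethyl on an aromatic nitrogen. All measured steps change a substituent on an aromatic carbon, not a group on the aromatic nitrogen, so none of them directly bears on this change; each was within the scatter. With no guidance, compound 4 is expected to give about 58% in this assay, between 40% and 72%, an expected step of a number 7 percentage points lower from compound 1 to compound 4 (within the scatter).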

Compound 4, a percentage reported as inhibition, in the whole organism at one dose (the size of the read-out at that dose, not a potency): 23%
Compound 4: the middle estimate sits 35 percentage points above what was measured; the whole stated range lies above it.
By their numbers in this assay, from the lowest: compound 4; then compounds 3, 2 and 1 (each within the scatter of the next).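

Every earlier change sat on an aromatic carbon and stayed within the scatter, but the change on the aromatic nitrogen does not: in this assay the step of a number 42 percentage points lower from compound 1 to compound 4 (beyond the scatter) shows that the group at this position can matter. At the one dose given, amino is a much poorer group here than ethyl. No measurement shown here explains this drop.

On these data alone, it remains open whether losing ethyl or gaining amino drives the drop. Methyl, propyl or a longer chain at this nitrogen, or a dimethylamino group, could help separate the two.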